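The compounds below may be only part of what the source reports. "The series", "measured", "known", "first", "only" and "open" are said of these compounds alone.

Of the compounds shown here, three have been measured in an assay on isolated protein for inhibition of vitamin D3 receptor (Homo sapiens), read by fluorescence polarization; on this read-out higher numbers stand for weaker inhibition and lower numbers for stronger inhibition. Compound 3 `CN(Cc1ccccc1)C(=O)CNC(=O)c1ccc(S(C)(=O)=O)c([N+](=O)[O-])c1` gives > 60000 nM, which is a limit of the assay rather than a number. Compound 2 `CS(=O)(=O)c1ccc(C(=O)NCC(=O)N(Cc2ccccc2)Cc2ccccc2)cc1[N+](=O)[O-]` gives > 60000 nM, again a limit. Compound 1 `CN(Cc1ccccc1)C(=O)C1CCN(C(=O)c2ccc(S(C)(=O)=O)c([N+](=O)[O-])c2)CC1`, built on a different core, gives > 60000 nM, also a limit. How the core of compound 1 differs from the core of compound 3 is not broken down here.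

From compound 3 to compound 2 the change is phenyl in place of hydrogen on a saturated chain carbon bound to an amide-type nitrogen. The step it made, a step that the two limits leave unreadable from compound 3 to compound 2, cannot be read, because both ends sit at the limit of > 60000 nM in this assay, at which 3 of the 3 values shown sit. All three measured values rest at that same limit, so none of them can be called stronger or weaker than another.

Compound 4 `CS(=O)(=O)c1ccc(C(=O)N2CCC(C(=O)N(Cc3ccccc3)Cc3ccccc3)CC2)cc1[N+](=O)[O-]` has not yet been measured in this assay. For the measured compounds named here, it differs from compound 1 by phenyl in place of hydrogen on a saturated chain carbon bound to an amide-type nitrogen, which is the same change as the one from compound 3 to compound 2, at the same place. The step from compound 1 to compound 4 is expected to be a step that the limit leaves unreadable from compound 1 to compound 4, set beside the earlier one, and that expectation rests on the measured step that the two limits leave unreadable from compound 3 to compound 2 being unreadable and on every shown value sitting at the limit of > 60000 nM in this assay, at which 3 of the 3 values shown sit. For compound 4 the estimate is 80000 nM, with an expected range from 20000 nM to 300000 nM, and the assay will most likely again report only a limit.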

Compound 4, half-maximal inhibitory concentration: > 60000 nM
Compound 4 ended at the assay's limit; the forecaster's own chance of this, stated with the estimate: 85%; the middle value does not contradict the limit.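

No new step can be read from compound 1 to compound 4, because in this assay both compounds, like compound 2 and compound 3, give only a limit rather than a number: the limit of > 60000 nM in this assay, at which 4 of the 4 values shown sit.

The compounds shown leave open whether phenyl in place of hydrogen at this place changes inhibition at all, and what structure would give a measurable value.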